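A few compounds are considered here, and "the series" means these few. Any claim that something is new, unique, unknown or untested is made for them only; others in the source may bear on it.

Measured in a functional assay on MDA-MB-231 cells (Homo sapiens) for cytotoxicity, read by MTT assay, with a stated time of 48 h; a lower number here means a stronger inhibitor, a higher number a weaker inhibitor:
- compound 1 `O=C(NCCCCC(c1ccc(F)cc1)c1ccc(F)cc1)Nc1ccc(I)cc1`: 11800 nM
- compound 2 `O=C(NCCCCC(c1ccc(F)cc1)c1ccc(F)cc1)Nc1ccc(C(F)(F)F)cc1`: 2780 nM

Not yet measured: compound 3 `O=C(NCCCCC(c1ccc(F)cc1)c1ccc(F)cc1)Nc1cccc([N+](=O)[O-])c1`.

Compound 2 holds the lower of the two numbers in this assay, at 2780 nM. The next change is 3-nitrophenyl in place of 4-(trifluoromethyl)phenyl on an amide-type nitrogen, with 3-nitrophenyl in place of 4-(trifluoromethyl)phenyl on an amide-type nitrogen. Among the compounds with values here, only one measured step bears on this aromatic group: a 4.2-fold lower number from compound 1 to compound 2 (0.63 log units; beyond the scatter). Within the data shown here, no measured compound carries a 3-nitrophenyl group, so that modest step sets only a rough size. A similarly modest rise in this assay is expected: a 1.8-fold higher number from compound 2 to compound 3 (0.25 log units; within the scatter). The estimated value for compound 3 is 5000 nM, with an expected range of 1800 nM to 14000 nM.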

Compound 3, half-maximal inhibitory concentration: 3790 nM
Beside the measured number, compound 3's estimate is 1.3-fold (0.12 log units) above it; measured number inside the range.
By their numbers in this assay, from the lowest: compounds 2 and 3 (each within the scatter of the next); then compound 1.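

In this assay, 3-nitrophenyl on an amide-type nitrogen stays level with 4-(trifluoromethyl)phenyl (a 1.4-fold higher number from compound 2 to compound 3 (0.13 log units; within the scatter)) and clearly improves on 4-iodophenyl (a 3.1-fold lower number from compound 1 to compound 3 (0.49 log units; beyond the scatter)). This place therefore takes a group with 2 hydrogen-bond acceptors in place of one with 0 hydrogen-bond acceptors, with no step beyond the scatter. Nothing available accounts for these readings.

From the compounds shown here alone, whether an amine or a carboxylic acid in place of the nitro group would hold this level stays open. So does the effect of a longer chain in the shared core.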